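The source may report more compounds than this note shows. Statements on the series, on what has been measured and on what is new or still open speak of the compounds shown alone.

Within the data shown here, compound 2 `O=C(Nc1cccc(-c2oc3cc(-c4ccc(F)cc4)ccc3c(=O)c2O)c1)c1ccc(C(F)(F)F)cc1` gives 33000 nM in a functional assay on GTL 16 cells for antiproliferative activity against GTL 16 cell line (Homo sapiens), read by CCK-8 assay, with a stated time of 72 h (a higher number here means a weaker inhibitor, a lower number a stronger inhibitor), the highest of the three numbers so far. Compound 1 `O=C(Nc1cccc(-c2oc3cc(-c4ccc(F)cc4)ccc3c(=O)c2O)c1)c1ccc(Cl)cc1` gives 9140 nM and compound 3 `O=C(Nc1cccc(-c2oc3cc(-c4ccc(F)cc4)ccc3c(=O)c2O)c1)c1ccc([N+](=O)[O-])cc1` gives 18200 nM. The step of a 3.6-fold higher number from compound 1 to compound 2 (0.56 log units; beyond the scatter) is the only one beyond the scatter; a 1.8-fold lower number from compound 2 to compound 3 (0.26 log units; within the scatter) and a 2.0-fold higher number from compound 1 to compound 3 (0.30 log units; within the scatter) both stay inside it. Compound 4 `CCCc1ccc(C(=O)Nc2cccc(-c3oc4cc(-c5ccc(F)cc5)ccc4c(=O)c3O)c2)cc1` differs from compound 2 by propyl in place of trifluoromethyl on an aromatic carbon. Among the measured compounds shown here, no measured step involves an alkyl group at this position, so the bearing steps are only those where trifluoromethyl is exchanged: both exchanges away from it gave lower or equal numbers. A modest drop or no change is therefore expected, a 2.2-fold lower number from compound 2 to compound 4 (0.34 log units; beyond the scatter). Compound 4 is estimated at 15000 nM, within 5000 nM to 45000 nM.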

Compound 4, half-maximal inhibitory concentration: 20400 nM
Beside the measured number, compound 4's estimate is 1.4-fold (0.13 log units) below it; the measured number falls inside the stated range.
By their numbers in this assay, from the lowest: compounds 1, 3, 4 and 2 (each within the scatter of the next, the first and the last beyond it).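

Propyl, the first alkyl group at this position, cannot be told apart in this assay from trifluoromethyl (a 1.6-fold lower number from compound 2 to compound 4 (0.21 log units; within the scatter)) or from nitro (a 1.1-fold higher number from compound 3 to compound 4 (0.05 log units; within the scatter)). Only chloro stands apart from it (a 2.2-fold higher number from compound 1 to compound 4 (0.35 log units; beyond the scatter)), so the chloro of compound 1 is separated from propyl and trifluoromethyl but not from the nitro of compound 3. Nothing available explains these steps.

On these data alone, whether an amine, a carboxylic acid or a longer chain at this position would give a number clearly apart from these four stays open. So does the effect of moving any of these groups elsewhere on the ring.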